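The compounds below may be only part of what the source reports. "The series", "measured", "known", "first", "only" and "open" are said of these compounds alone.

Measured so far in an assay on membranes from Cerebral cortex for displacement of a labelled ligand from Neuronal acetylcholine receptor; alpha4/beta2 (Rattus norvegicus), with a stated time of 5 min; a lower number here means a stronger inhibitor, a higher number a weaker inhibitor:

compound 1, `CN1CCC[C@H]1[C@@H]1COc2ccc(N)cc2O1`: 22 nM
compound 2, `CN1CCC[C@H]1[C@H]1COc2ccc(N)cc2O1`: 140 nM
compound 3, `CN1CCC[C@H]1[C@@H]1COc2c(N)cccc2O1`: 7100 nM

Among these three numbers compound 2 stands second highest. Its nearest neighbour is compound 1, whose number is lower, and the step from one to the other is a 6.4-fold higher number from compound 1 to compound 2 (0.80 log units; beyond the scatter); this step rests on nothing but (the fact that compounds 1 and 2 differ only in the configuration as drawn). Furthest away is compound 3, whose number in this assay is the highest of the three, as the values above show.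

Compound 4, `CN1CCC[C@H]1[C@H]1COc2ccc([N+](=O)[O-])cc2O1`, has not yet been measured. It departs from compound 2 by nitro in place of amino on an aromatic carbon. For the measured compounds named here, none of the measured steps concerns a change of substituent: the one step on record, from compound 1 to compound 2, changes only the configuration at a saturated ring carbon, and the pair compound 1 and compound 3 differs in where the amino group sits, with no step computed for it. Going by the values given here, the replacement of amino by nitro therefore has no measured counterpart here, and the expectation for compound 4 must stay wide. The step expected from compound 2 to compound 4 in this assay is a 2.9-fold higher number from compound 2 to compound 4 (0.46 log units; beyond the scatter), a modest rise with a broad margin on either side. Compound 4 is accordingly estimated at 400 nM, with a likely range from 60 nM to 3000 nM.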

Compound 4, inhibition constant: 33000 nM
Beside the measured number, compound 4's estimate is 83-fold (1.92 log units) below it; the whole stated range lies below it.
By their numbers in this assay, from the lowest: compound 1; then compound 2; then compound 3; then compound 4.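

At this aromatic carbon, the group present matters a great deal in this assay: replacing amino with nitro gives a 240-fold higher number from compound 2 to compound 4 (2.37 log units; beyond the scatter), a large step, whereas the change of configuration alone gives the modest 6.4-fold higher number from compound 1 to compound 2 (0.80 log units; beyond the scatter). The swap removes the hydrogen-bond donor of the amino group, since nitro has none, and it also brings in more heavy atoms, so two things change at once at this single carbon. Nothing shown here explains why the replacement has so strong an effect on the number, as the only supporting information concerns configuration rather than this change of substituent.

As far as these compounds go, it remains open where a hydroxyl group or a methyl group on this same carbon would fall relative to compound 2 and compound 4, which could help to separate the loss of amino from the arrival of nitro. From the compounds shown here alone, it is also open whether nitro would give a similarly large step in the configuration of compound 1, since the change has been followed here only in the configuration of compound 2.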